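This account rests on a few compounds, and the source may have more. Where it says the series, first, only, none or still open, it means among the compounds named here.

Measured so far in a functional assay on cells (Neutrophil, Homo sapiens) for inhibition, with a stated time of 10 min; a lower number here means a stronger inhibitor, a higher number a weaker inhibitor:
- compound 1 `CCOC(=O)c1cnn(C)c1NC(=O)NCc1ccccc1`: 18 nM
- compound 2 `CCOC(=O)c1cnn(CC(C)O)c1NC(=O)Nc1cccc(F)c1`: > 10 nM
- compound 3 `CCOC(=O)c1cnn(CC(O)CC)c1NC(=O)Nc1cccc(F)c1`: 0.19 nM

Where compound 2 stands: in this assay the value of compound 2 is a limit and not a number, and the limit of > 10 nM in this assay, at which 1 of the 3 values shown sits, describes this value. Compound 3 sits at the strong end of the three, compound 1 between the two.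

Among the compounds with values here, the one step computed between measured compounds runs an at least 52-fold lower number from compound 2 to compound 3 (1.72 log units; beyond the scatter) and concerns the chain on the ring nitrogen, not the amide-type nitrogen.

Compound 4 `CCOC(=O)c1cnn(CC(C)O)c1NC(=O)NC(C)C` differs from compound 2 by isopropyl in place of 3-fluorophenyl on an amide-type nitrogen. Within the data shown here, no measured step changes the group on the amide-type nitrogen while the rest is held constant; compound 1 carries benzyl there but also a different group on the ring nitrogen, so its value cannot be read as a step to compound 2 or compound 4. The expectation for compound 4 therefore rests only on the position of compound 2 at the limit and on the range spanned by compound 1 and compound 3, and is wide.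

Compound 4 is estimated at 40 nM with a range of 5 nM to 400 nM. The step expected from the limit of compound 2 is a step that the limit leaves unreadable from compound 2 to compound 4, with little confidence in its direction.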

Compound 4, half-maximal inhibitory concentration: 90 nM
Compound 4: middle estimate off by 2.3-fold (0.35 log units), on the low side, within the range that was stated.
By their numbers in this assay, from the lowest: compound 3; then compound 1; then compound 4.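

The step from compound 2 to compound 4 cannot be read in this assay, since the value of compound 2 is a limit and not a number: the limit of > 10 nM in this assay, at which 1 of the 4 values shown sits.

The compounds shown leave open how far isopropyl in place of 3-fluorophenyl on an amide-type nitrogen moves the number while the rest is held constant.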